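The compounds below may be only part of what the source reports. "The series", "measured", "known", "first", "only" and "open" are said of these compounds alone.

For the measured compounds named here, compound 2 `COc1ccc(C(=O)/C=C/c2cc(-c3cc(OC)c(OC)c(OC)c3)n[nH]2)cc1OC` gives 49900 nM in a functional assay on OVCAR-4 cells (Homo sapiens) for inhibition, read by sulforhodamine B assay, with a stated time of 48 h (on this read-out lower numbers stand for higher toxicity in this test and higher numbers for lower toxicity in this test), the higher of the two numbers seen so far; compound 1 `COc1cc(-c2cc(/C=C/C(=O)c3ccc(N)cc3)[nH]n2)cc(OC)c1OC` gives 23700 nM in this assay, and the only measured step, a 2.1-fold higher number from compound 1 to compound 2 (0.32 log units; beyond the scatter), concerns a different exchange. Compound 3 `COc1cc(C(=O)/C=C/c2cc(-c3cc(OC)c(OC)c(OC)c3)n[nH]2)cc(OC)c1OC` differs from compound 2 by methoxy in place of hydrogen on an aromatic carbon. Going by the values given here, no measured step bears directly on this change, so no step beyond the scatter is expected in this assay. Compound 3 is therefore estimated at 42000 nM, within 15000 nM to 120000 nM, which corresponds to an expected step of a 1.2-fold lower number from compound 2 to compound 3 (0.07 log units; within the scatter).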

Compound 3, concentration lethal to 50% of the cells: 5250 nM
For compound 3 the middle estimate is 8.0-fold (0.90 log units) above the measured one; the whole stated range lies above it.
By their numbers in this assay, from the lowest: compound 3; then compound 1; then compound 2.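

Methoxy in place of hydrogen on this aromatic carbon, ortho to a methoxy group, gives a 9.5-fold lower number from compound 2 to compound 3 (0.98 log units; beyond the scatter) in this assay, so this single added group moves the number beyond the scatter. The earlier compounds shown here showed only the exchange of one whole group on the carbonyl carbon, not the effect of one added methoxy at this position. No evidence at hand explains this step. As far as these compounds go, it remains open whether a hydroxyl, a fluorine or an amine at this position would give a step of like size, and whether an ethoxy would do the same.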